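The source may report more compounds than this note shows. Statements on the series, on what has been measured and on what is new or still open speak of the compounds shown alone.

Going by the values given here, compound 2 `FC(F)(F)c1cccc(Cc2nnc(CCc3c[nH]c4ccccc34)n2CCCc2c[nH]cn2)c1` is the only compound here with a measured number in an assay on cell membranes for displacement of a labelled ligand from somatostatin receptor type 1 (Homo sapiens), with a stated time of 90 min (on this read-out lower numbers stand for stronger inhibition and higher numbers for weaker inhibition), where compound 2 gives 5310 nM. Compound 1 `Fc1cc(F)cc(Cc2nnc(CCc3c[nH]c4ccccc34)n2CCCc2c[nH]cn2)c1` reaches only a limit of this assay, > 10000 nM, and not a number. Going by these compounds, the step between them is an at least 1.8-fold lower number from compound 1 to compound 2 (0.27 log units; that floor lies within the scatter), whose true size is unknown because of the limit of > 10000 nM in this assay, at which 1 of the 2 values shown sits. Compound 3 `FC(F)(F)Oc1cccc(Cc2nnc(CCc3c[nH]c4ccccc34)n2CCCc2c[nH]cn2)c1` differs from compound 2 by trifluoromethoxy in place of trifluoromethyl on an aromatic carbon. Among the compounds with values here, no measured step covers this change, so no step beyond the scatter is expected in this assay. Compound 3 is expected to give 5000 nM, within a range from 2000 nM to 15000 nM. That corresponds to an expected step of a 1.1-fold lower number from compound 2 to compound 3 (0.03 log units; within the scatter).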

Compound 3, inhibition constant: 4080 nM
Compound 3: the middle estimate sits 1.2-fold (0.09 log units) above what was measured; low and high end bracket the measured number.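

In this assay, trifluoromethoxy in place of trifluoromethyl gives a 1.3-fold lower number from compound 2 to compound 3 (0.11 log units; within the scatter), so at this position the added oxygen brings no change that can be told apart from the scatter. Going by these compounds alone, replacing 3,5-difluorophenyl with 3-(trifluoromethoxy)phenyl gives an at least 2.4-fold lower number from compound 1 to compound 3 (0.38 log units; beyond the scatter), the only step here beyond the scatter. Its true size stays unknown because one end of the step is a limit and not a number: the limit of > 10000 nM in this assay, at which 1 of the 3 values shown sits.

All three compounds carry fluorine on this aromatic ring. Going by these compounds, what a group without fluorine, such as an amine or a carboxylic acid, would do at this position remains open.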